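Amide series at MCH receptor: amine variation on the core

The compounds below may be only part of what the source reports. "The series", "measured", "known", "first", "only" and "open" are said of these compounds alone.

Values in a functional assay on HEK293 cells for activation of melanin-concentrating hormone receptor 1 (Rattus norvegicus), read by inositol phosphate accumulation (a higher number here means that more compound is needed for the effect, a lower number that less compound is needed), for the measured compounds:
compound 1 `CN(c1ccc2cc(NC(=O)CCc3ccc(C(F)(F)F)cc3)ccc2n1)C1CCCC1` gives 350 nM
compound 2 `O=C(CCc1ccc(C(F)(F)F)cc1)Nc1ccc2nc(N3CCC(c4ccccc4)C3)ccc2c1` gives 1770 nM
compound 3 `Nc1ccc2cc(NC(=O)CCc3ccc(C(F)(F)F)cc3)ccc2n1` gives 720 nM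

All three share the amide chain and the bicyclic core and differ only in the amine on the aromatic carbon. Compound 3 stands second highest of the three numbers: the step of a 2.1-fold higher number from compound 1 to compound 3 (0.31 log units; beyond the scatter) separates it from compound 1, and the step of a 2.5-fold lower number from compound 2 to compound 3 (0.39 log units; beyond the scatter) from compound 2, so the cyclic amine of compound 2 sits on the higher side and the open amine of compound 1 on the lower side of compound 3.

Compound 4 `O=C(CCc1ccc(C(F)(F)F)cc1)Nc1ccc2nc(N3CCC4(CCNC4)C3)ccc2c1` is the next member. The change from compound 3 is a group of 9 heavy atoms (7 carbon, 2 nitrogen; 2 five-membered non-aromatic rings with 1 hetero atom each) in place of one nitrogen atom, on an aromatic carbon. For the measured compounds named here, two steps bear on it: the cyclic amine of compound 2 raised the number relative to compound 3 (a 2.5-fold lower number from compound 2 to compound 3 (0.39 log units; beyond the scatter) read backwards), while the cyclopentyl(methyl)amino of compound 1 lowered it (a 2.1-fold higher number from compound 1 to compound 3 (0.31 log units; beyond the scatter)). The entering group of compound 4 is again cyclic, so a modest rise in this assay is expected, a 1.4-fold higher number from compound 3 to compound 4 (0.14 log units; within the scatter). Compound 4 is estimated at 1000 nM, within 350 nM to 3000 nM.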

Compound 4, half-maximal effective concentration: 140 nM
Compound 4: the middle estimate sits 7.1-fold (0.85 log units) above what was measured; the whole stated range lies above it.
By their numbers in this assay, from the lowest: compound 4; then compound 1; then compound 3; then compound 2.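

In this assay, a cyclic amine on this aromatic carbon next to the ring nitrogen need not raise the number: the entering group of two five-membered non-aromatic rings gives the opposite of the rise seen with compound 2 (a 5.1-fold lower number from compound 3 to compound 4 (0.71 log units; beyond the scatter)). The two cyclic groups are far apart (a 13-fold lower number from compound 2 to compound 4 (1.10 log units; beyond the scatter)), so the outcome depends on which cyclic group enters, and the new group also goes past the open amine (a 2.5-fold lower number from compound 1 to compound 4 (0.40 log units; beyond the scatter)), leaving compound 4 lowest of the four, with all its steps beyond the scatter. Nothing at hand accounts for these steps.

On these data alone, it remains open whether the second nitrogen of the entering group or its two-ring frame carries the drop. The same frame with carbon in place of that nitrogen, a methyl on it, or a simple piperazine would separate the two.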